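Growth inhibition notes: the step to compound 4

The source may report more compounds than this note shows. Statements on the series, on what has been measured and on what is new or still open speak of the compounds shown alone.

In a functional assay on SK-MEL-28 cells (Homo sapiens) for inhibition, read by sulforhodamine B assay, with a stated time of 48 h (a higher number here means a weaker inhibitor of growth, a lower number a stronger inhibitor of growth), compound 1 `O=C(Cc1csc2nc(-c3ccc(Br)cc3)cn12)N/N=C/c1ccccc1` gives > 100000 nM, which is a limit of the assay and not a number. Compound 2 `O=C(Cc1csc2nc(-c3ccc(Br)cc3)cn12)N/N=C/c1ccccc1O` gives 24000 nM. Compound 3 `O=C(Cc1csc2nc(-c3ccc(Br)cc3)cn12)N/N=C/c1ccc(O)cc1` gives 100000 nM, the higher of the two actual numbers in the series. The gap to its nearest neighbour is a 4.2-fold higher number from compound 2 to compound 3 (0.62 log units; beyond the scatter).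

Compound 4 `COc1cccc(OC)c1/C=N/NC(=O)Cc1csc2nc(-c3ccc(Br)cc3)cn12` has not yet been measured. Its structural change is 2,6-dimethoxyphenyl in place of 4-hydroxyphenyl on a carbon with a double bond to nitrogen.

All three measured steps concern the group on that same carbon. Placing hydroxy on the aromatic ring gave an at least 4.1-fold lower number from compound 1 to compound 2 (0.61 log units; beyond the scatter), while the corresponding step to 4-hydroxyphenyl was a number no higher from compound 1 to compound 3 (the limit leaves the size open), its size left open by the limit. For the measured compounds named here, no measured compound carries a methoxy group, so these steps transfer only loosely to the new group. A modest lean towards a lower number is expected in this assay, resting on compound 2 at 24000 nM, with no step beyond the scatter firmly expected. The estimated step is a 1.7-fold lower number from compound 3 to compound 4 (0.22 log units; within the scatter). For compound 4 the expected value is 60000 nM, with an estimated range of 20000 nM to 100000 nM.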

Compound 4, concentration for total growth inhibition: > 100000 nM
Compound 4 ended at the assay's limit; the forecaster's own chance of this, stated with the estimate: 35%; middle value at least 1.6-fold (0.22 log units) from the limit.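

At the carbon with a double bond to nitrogen, 2,6-dimethoxyphenyl does not keep the gain seen with 2-hydroxyphenyl, with an at least 4.1-fold higher number from compound 2 to compound 4 (0.61 log units; beyond the scatter) in this assay, and 2-hydroxyphenyl remains the only group shown that stands clear of all the others. Against the 4-hydroxyphenyl group the result gives only a direction, a number no lower from compound 3 to compound 4 (the limit leaves the size open), and the step from the unsubstituted phenyl of compound 1 cannot be read. Compound 4 joins compound 1 at a limit of the assay rather than a number, so the two cannot be ordered against each other: the limit of > 100000 nM in this assay, at which 2 of the 4 values shown sit.

The change to compound 4 removes the hydroxy and adds two methoxy groups in one step, so the series does not show which part of it costs the growth inhibition seen with 2-hydroxyphenyl. From the compounds shown here alone, a phenyl ring with a single methoxy group, or with an amine or a carboxylic acid in place of the hydroxy, would separate these parts, and how far any of them would fall below the limit remains open.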